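The source may report more compounds than this note shows. Statements on the series, on what has been measured and on what is new or still open speak of the compounds shown alone.

Measured compounds in this series:
- compound 1, `O=S(=O)(Nc1ccc(-c2nc3ccccc3o2)cc1)c1cccc(F)c1`; in an assay on isolated protein for inhibition of malate dehydrogenase, mitochondrial (Sus scrofa), with stated times of 45 min and 30 min (a higher number here means a weaker inhibitor, a lower number a stronger inhibitor), compound 1 gives > 63000 nM, a limit of the assay
- compound 2, `O=S(=O)(Nc1ccc(-c2nc3ccccc3o2)cc1)c1cccc(Cl)c1`; in this assay compound 2 gives > 63000 nM, a limit of the assay
- compound 3, `O=S(=O)(Nc1ccc(-c2nc3ccccc3o2)cc1)c1ccccc1O`; in this assay compound 3 gives > 63000 nM, a limit of the assay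

Compound 3 stands at the assay limit, with no number to place it against the others; (the limit of > 63000 nM in this assay, at which 3 of the 3 values shown sit). The steps a step that the two limits leave unreadable from compound 1 to compound 2, a step that the two limits leave unreadable from compound 1 to compound 3 and a step that the two limits leave unreadable from compound 2 to compound 3 are therefore unreadable.

Compound 4, `O=S(=O)(Nc1ccc(-c2nc3ccccc3o2)cc1)c1ccc(F)cc1`, differs from compound 3 by 4-fluorophenyl in place of 2-hydroxyphenyl on a sulfonyl sulfur. Going by the values given here, the steps from compound 1 to compound 3 and from compound 2 to compound 3 bear on this position, but both are unreadable, so no size of step in this assay can be read from them. Compound 4 is expected to sit at the limit as well, the estimate being 100000 nM with a range of 30000 nM to 400000 nM. The expected step is a step that the limit leaves unreadable from compound 3 to compound 4, read as none beyond the scatter.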

Compound 4, half-maximal inhibitory concentration: > 63000 nM
Compound 4: only a limit was reported (the forecaster's own chance of this, stated with the estimate: 85%); the middle value does not contradict the limit.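

The steps from compound 1, compound 2 and compound 3 to compound 4 cannot be read, with all four compounds at an assay limit: the limit of > 63000 nM in this assay, at which 4 of the 4 values shown sit.
Open remains whether any group on the sulfonyl sulfur gives a measurable value in this assay and how large such a step would be.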